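The source may report more compounds than this note shows. Statements on the series, on what has been measured and on what is new or still open speak of the compounds shown alone.

Measured compounds and their numbers from an ADME assay on Vero cells (Chlorocebus sabaeus) for cytotoxicity, read by MTT assay, with a stated time of 72 h; a lower number here means that less compound is tolerated, a higher number that more compound is tolerated:

compound 1 `N/C(=N/NC(CC(=O)c1ccc(-n2ccnc2)cc1)c1ccc(Cl)cc1Cl)c1ccccn1` — 27800 nM
compound 2 `N/C(=N/NC(CC(=O)c1ccc(-n2ccnc2)cc1)c1cccc([N+](=O)[O-])c1)c1ccccn1` — 28700 nM
compound 3 `N/C(=N/NC(CC(=O)c1ccc(-n2ccnc2)cc1)c1ccccc1Br)c1ccccn1` — 29000 nM

Compound 2 stands second highest of these three numbers. Its nearest neighbour is compound 3, with a 1.0-fold higher number from compound 2 to compound 3 (0.00 log units; within the scatter); the step of a 1.0-fold higher number from compound 1 to compound 2 (0.01 log units; within the scatter) is likewise within the scatter, as is a 1.0-fold higher number from compound 1 to compound 3 (0.02 log units; within the scatter).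

Compound 4 `N/C(=N/NC(CC(=O)c1ccc(-n2ccnc2)cc1)c1ccccc1F)c1ccccn1` differs from compound 2 in one place: 2-fluorophenyl in place of 3-nitrophenyl on a saturated chain carbon bound to an amine nitrogen and a saturated chain carbon. The three measured steps all exchange the aryl group at this same position, and none moves the number beyond the scatter. The expected step is therefore none beyond the scatter, a 1.0-fold lower number from compound 2 to compound 4 (0.00 log units; within the scatter). Compound 4 is estimated to give 28500 nM in this assay, within a range from 14000 nM to 57000 nM.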

Compound 4, half-maximal cytotoxic concentration: 62100 nM
For compound 4 the middle estimate is 2.2-fold (0.34 log units) below the measured one, outside the stated range (above it).
By their numbers in this assay, from the lowest: compounds 1, 2 and 3 (each within the scatter of the next); then compound 4.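

In this assay the aryl group on this saturated chain carbon can move the number beyond the scatter after all: 2-fluorophenyl gives a 2.2-fold higher number from compound 2 to compound 4 (0.34 log units; beyond the scatter), a 2.1-fold higher number from compound 3 to compound 4 (0.33 log units; beyond the scatter) and a 2.2-fold higher number from compound 1 to compound 4 (0.35 log units; beyond the scatter). The step from compound 3 is only fluoro in place of bromo on an aromatic carbon, so exchanging that one atom is enough to set compound 4 apart, though no measurement shown gives a reason for it. Still open, going by these compounds, is whether an unsubstituted phenyl, or a phenyl carrying a methoxy group or an amine, would stand with compound 4 or with the other three.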